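The source may report more compounds than this note shows. Statements on the series, on what has been measured and on what is new or still open speak of the compounds shown alone.

Compound 1, `COc1ccc(-c2cc3ccccc3nc2/C=C/C(=O)c2ccccc2)cc1`: 700 nM
Compound 2, `COc1ccc(-c2cc3ccccc3nc2/C=C/C(=O)c2ccc(F)cc2)cc1`: 810 nM

Both compounds were tested in a functional assay on SK-BR-3 cells (Homo sapiens) for antiproliferative activity, read by XTT assay, with a stated time of 72 h; on this read-out lower numbers stand for stronger inhibition and higher numbers for weaker inhibition. Compound 2 gives the higher of the two numbers, but the step of a 1.2-fold higher number from compound 1 to compound 2 (0.06 log units; within the scatter) lies within the scatter, so the two compounds cannot really be told apart on this read-out.

Compound 3, `COc1ccc(-c2cc3ccccc3nc2/C=C/C(=O)c2ccc(O)cc2)cc1`, has not yet been measured. It differs from compound 2 in one place: hydroxy in place of fluoro on an aromatic carbon. For the measured compounds named here, the only measured step that touches this position is a 1.2-fold higher number from compound 1 to compound 2 (0.06 log units; within the scatter), in which a hydrogen at the same aromatic carbon was exchanged for fluoro without a change beyond the scatter. Going by the values given here, no measured step swaps fluoro for hydroxy, so there is no direct guide for the hydrogen-bond donor and acceptor that enter. Among the compounds with values here, with a single, flat step as the only evidence, the expectation for the step from compound 2 to compound 3 in this assay is a 1.0-fold lower number from compound 2 to compound 3 (0.01 log units; within the scatter), that is, nothing beyond the scatter in either direction. Compound 3 is therefore estimated at 800 nM in this assay, with a range from 300 nM to 2200 nM.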

Compound 3, half-maximal inhibitory concentration: 3880 nM
Compound 3: middle estimate off by 4.9-fold (0.69 log units), on the low side, and the stated range ends below it.
By their numbers in this assay, from the lowest: compounds 1 and 2 (each within the scatter of the next); then compound 3.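

The position does respond to what sits on it, and the response depends on the group. In this assay, hydroxy on this aromatic carbon gives a 4.8-fold higher number from compound 2 to compound 3 (0.68 log units; beyond the scatter) and a 5.5-fold higher number from compound 1 to compound 3 (0.74 log units; beyond the scatter), both beyond the scatter and toward weaker inhibition, whereas hydrogen and fluoro could not be told apart. Of the two groups exchanged in the latest step, only hydroxy counts a hydrogen-bond donor and a hydrogen-bond acceptor, but the data at hand offer no explanation for the weaker inhibition.

The compounds shown leave open whether this loss is specific to hydroxy or would also appear with other groups on the same carbon, such as methoxy, an amine or a carboxylic acid. They also leave open whether hydroxy would give a similar step on a different aromatic carbon of the same ring, or whether the effect belongs to this one place.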